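The source may report more compounds than this note shows. Statements on the series, on what has been measured and on what is new or still open speak of the compounds shown alone.

Measured so far in the series:
compound 1 `CCN1CCN(c2cc(C)c3cc(NC(=O)c4cccnc4)ccc3n2)CC1`, 10600 nM
compound 2 `Cc1cc(NCCN2CCN(C)CC2)nc2ccc(NC(=O)c3ccc(Cl)c(Cl)c3)cc12`, 2690 nM
compound 3 `Cc1cc(N2CCN(C)CC2)nc2ccc(NC(=O)c3ccc(Cl)c(Cl)c3)cc12`, 6320 nM

In a functional assay on SK-BR-3 cells (Homo sapiens) for antiproliferative activity, read by MTT assay, with a stated time of 72 h (on this read-out lower numbers stand for stronger inhibition and higher numbers for weaker inhibition), compound 1 gives the highest number of the three; compound 3 sits within the scatter of it, while compound 2 lies beyond it on the lower side. Compound 4 `CCN1CCN(c2cc(C)c3cc(NC(=O)c4ccc(Cl)cc4)ccc3n2)CC1` arises from compound 1 by 4-chlorophenyl in place of pyridin-3-yl on a carbonyl carbon. Within the data shown here, the only measured step, a 2.3-fold higher number from compound 2 to compound 3 (0.37 log units; beyond the scatter), concerns the piperazine-bearing side chain and not the amide aryl, so it does not bear on this change. Among the measured compounds shown here, compounds 1 and 3 differ both in the amide aryl and in the piperazine substituent and give numbers within the scatter of each other; no pair isolates the amide aryl alone. A step no larger than the scatter, in either direction, is therefore expected in this assay. For compound 4 the expected value is 7000 nM, with a range of 2500 nM to 18000 nM, which amounts to an expected 1.5-fold lower number from compound 1 to compound 4 (0.18 log units; within the scatter).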

Compound 4, half-maximal inhibitory concentration: 3020 nM
The estimate for compound 4 lay 2.3-fold (0.37 log units) above the measured number; the measured number falls inside the stated range.
By their numbers in this assay, from the lowest: compounds 2 and 4 (each within the scatter of the next); then compounds 3 and 1 (each within the scatter of the next).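

In this assay, 4-chlorophenyl in place of pyridin-3-yl on a carbonyl carbon gives a 3.5-fold lower number from compound 1 to compound 4 (0.55 log units; beyond the scatter), so this position responds to the aryl group. Earlier pairs changed the amide aryl only together with the piperazine-bearing side chain, whereas this pair holds that side chain and the rest of the core fixed and isolates the amide aryl alone.

Still open, on these data alone, is how an unsubstituted phenyl, or a phenyl carrying a methoxy group or an amine in place of chlorine, would read on this carbonyl carbon. No measurement at hand accounts for the size of this step.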